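This account rests on a few compounds, and the source may have more. Where it says the series, first, only, none or still open, it means among the compounds named here.

Measured so far:
compound 1 `C1=NCC(CC2=Cc3ccccc3CC2)N1` — 398 nM
compound 2 `Cc1cccc2c1C=C(CC1CN=CN1)CC2` — 631 nM

In an assay on isolated protein for binding affinity to Adrenergic receptor alpha-1 (Rattus norvegicus), read by radioligand binding, in the presence of a further agent that is not named here (a higher number here means a weaker inhibitor, a lower number a stronger inhibitor), compound 1 gives 398 nM, the lower of the two numbers at hand. Compound 2 gives 631 nM in this assay, and the step of a 1.6-fold higher number from compound 1 to compound 2 (0.20 log units; within the scatter) stays within the scatter, so the two compounds cannot be ranked against each other.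

Compound 3 `CC1(CC2=Cc3ccccc3CC2)CN=CN1` differs from compound 1 in one place: methyl in place of hydrogen on a saturated ring carbon. Among the compounds with values here, the only measured step of a comparable kind is a 1.6-fold higher number from compound 1 to compound 2 (0.20 log units; within the scatter), where a methyl also replaced a hydrogen, though on an aromatic carbon rather than on the saturated ring carbon concerned here. That step was within the scatter. Within the data shown here, no measured pair speaks to a methyl on the saturated ring itself, so the expectation rests on the one small step seen. Compound 3 is therefore expected to show at most a modest rise, a 1.6-fold higher number from compound 1 to compound 3 (0.20 log units; within the scatter), in this assay, and its estimated value is 630 nM, within a range of 200 nM to 2000 nM.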

Compound 3, inhibition constant: 1260 nM
Estimate against measurement, compound 3: 2.0-fold (0.30 log units) below, and the stated range covers the measured number.
By their numbers in this assay, from the lowest: compounds 1, 2 and 3 (each within the scatter of the next, the first and the last beyond it).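

In this assay, methyl in place of hydrogen on a saturated ring carbon of the five-membered non-aromatic ring with 2 nitrogen gives a 3.2-fold higher number from compound 1 to compound 3 (0.50 log units; beyond the scatter), the first step among these compounds to lie beyond the scatter. This position therefore responds to the addition of a single methyl, whereas methyl on an aromatic carbon, with a 1.6-fold higher number from compound 1 to compound 2 (0.20 log units; within the scatter), does not separate from compound 1. Nothing at hand gives a reason for this step.

The compounds shown leave open whether a longer chain such as ethyl on the same saturated ring carbon would raise the number further or whether the step is limited to methyl. They also leave open how a hydroxyl, an amine or a carboxylic acid would read there in place of the hydrogen.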